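Benzylcarbamoyl for benzyl: expectation for compound 3

The source may hold more compounds than are shown below. What is called first, only, known or untested is meant among the compounds shown, and "the series" means these compounds.

Two compounds of the series carry numbers in an assay on nucleic acid for inhibition of Nucleic Acid, read by fluorescence, tested at 100 uM; a higher number here means more inhibition at the concentration tested (going by the name of the read-out), a lower number less inhibition. Compound 1 `CC(C)CCN(C)Cc1cn(C2CCCCC2O)nn1` gives 42%. Compound 2 `OC(COCc1ccccc1)Cn1cc(CN2CCN(c3ccccc3)CC2)nn1` gives 37%, the lowest of the two numbers; its nearest neighbour is compound 1, whose number is higher by an amount that lies within the usual scatter, so the two read as alike rather than ordered. Among the compounds with values here, no pair of measured compounds differs in a single place, so the size of any one structural change cannot be read from the data.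

Compound 3 `O=C(NCc1ccccc1)OCC(O)Cn1cc(CN2CCN(c3ccccc3)CC2)nn1` is the untested member. It differs from compound 2 in one place: benzylcarbamoyl in place of benzyl on an oxygen on a saturated carbon. Nothing measured bears on this change, and the step is therefore expected to be small, so the number for compound 3 is expected to be level with that of compound 2 rather than higher or lower beyond the scatter. The expected step in this assay is a number 3 percentage points higher from compound 2 to compound 3 (within the scatter). Compound 3 is estimated at 40% in this assay. The range for compound 3 is expected to run from 20% to 60%, wide enough to cover readings on either side of the present numbers.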

Compound 3, a percentage reported as inhibition, at one concentration (the size of the read-out at that concentration, not a potency): 32%
The estimate for compound 3 lay 8 percentage points above the measured number; low and high end bracket the measured number.
By their numbers in this assay, from the lowest: compounds 3, 2 and 1 (each within the scatter of the next).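

In this assay, the series now has its first comparison of compounds that differ in one place: benzylcarbamoyl in place of benzyl on an oxygen on a saturated carbon gives a number 5 percentage points lower from compound 2 to compound 3 (within the scatter). At this position, therefore, a larger group that brings a carbonyl, a hydrogen-bond donor and a hydrogen-bond acceptor while keeping the six-membered aromatic ring leaves compound 2 and compound 3 reading alike, so this one change gives no sign that the read-out depends on the group on this oxygen. No measurement on hand gives a reason for this reading.

From the compounds shown here alone, with only benzyl and benzylcarbamoyl compared on this oxygen, it remains open whether a group without an aromatic ring, such as an amine, a carboxylic acid or a longer saturated chain, would separate from compound 2 beyond the scatter. Each compound is also read at a single concentration, so the data leave open whether compound 2 and compound 3 would still read alike at other concentrations.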